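A few compounds are considered here, and "the series" means these few. Any claim that something is new, unique, unknown or untested is made for them only; others in the source may bear on it.

Two compounds have been measured so far in a functional assay (Homo sapiens) for inhibition; a higher number here means a weaker inhibitor, a lower number a stronger inhibitor:

Compound 1 `COc1ccc(/C=C/C(=O)c2cccc(Br)c2)c(OC)c1`: 37000 nM
Compound 2 `COc1cc(OC)c(/C=C/C(=O)c2ccc(O)cc2)c(OC)c1`: 44000 nM

Compound 2 stands level with compound 1, since the two values lie within the scatter of each other and cannot be ranked. Compound 3 `COc1ccc(/C=C/C(=O)c2ccc(O)cc2)c(OC)c1` differs from compound 2 by having hydrogen in place of methoxy on an aromatic carbon, ortho to a large group and meta to two methoxy groups (hydrogen in place of methoxy on an aromatic carbon). Among the compounds with values here, no two measured compounds differ in one place only, so this change has not been seen directly. Compound 1 (37000 nM) and compound 2 (44000 nM) differ in more than one place, yet their values fall within the scatter. On that basis, no shift beyond the scatter is expected in this assay in either direction. The estimate amounts to a 1.1-fold lower number from compound 2 to compound 3 (0.04 log units; within the scatter) and is expected to stay within the scatter. For compound 3 the estimated value is 40000 nM (expected range 15000 nM to 100000 nM).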

Compound 3, half-maximal inhibitory concentration: 71000 nM
For compound 3 the middle estimate is 1.8-fold (0.25 log units) below the measured one, within the range that was stated.
By their numbers in this assay, from the lowest: compounds 1, 2 and 3 (each within the scatter of the next).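

In this assay, within the data shown here, the step of a 1.6-fold higher number from compound 2 to compound 3 (0.21 log units; within the scatter) gives the first direct reading of hydrogen in place of methoxy on this aromatic carbon, ortho to a large group, and it stays within the scatter. The compounds therefore give no sign that the number depends on this methoxy group. Likewise, 4-hydroxyphenyl in place of 3-bromophenyl on a carbonyl carbon gives a 1.9-fold higher number from compound 1 to compound 3 (0.28 log units; within the scatter), which is also within the scatter, and no measurement at hand offers an explanation for either result.

Still open, on these data alone, is whether an amine or a carboxylic acid on the same aromatic carbon would shift the number beyond the scatter. As far as these compounds go, it is also open whether a longer chain, such as butoxy, would do so in place of the methoxy group at this position.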